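This account rests on a few compounds, and the source may have more. Where it says the series, first, only, none or still open, it means among the compounds named here.

For the measured compounds named here, compound 3 `Cc1cc(Nc2nc(NCc3cc(F)ccc3F)nc3ccccc23)n[nH]1` gives the lowest number of the three measured so far in an assay for inhibition of high affinity nerve growth factor receptor (Homo sapiens), read by HTRF, with a stated time of 30 min, in the presence of a further agent that is not named here (a higher number here means a weaker inhibitor, a lower number a stronger inhibitor), at 7.5 nM. Compound 1 `Cc1cc(Nc2nc(NCc3ccc(F)cc3)nc3ccccc23)n[nH]1` gives 20 nM, and compound 2 `Cc1cc(Nc2nc(NCc3ccc(F)cc3F)nc3ccccc23)n[nH]1` gives 200 nM. The step of a 2.7-fold lower number from compound 1 to compound 3 (0.43 log units; beyond the scatter) and the step of a 27-fold lower number from compound 2 to compound 3 (1.43 log units; beyond the scatter) both end at compound 3, whereas a 10-fold higher number from compound 1 to compound 2 (1.00 log units; beyond the scatter) went the other way. Compound 4 `Cc1cc(Nc2nc(NCc3c(F)cccc3F)nc3ccccc23)n[nH]1` differs from compound 3 by 2,6-difluorophenyl in place of 2,5-difluorophenyl on a saturated chain carbon bound to a nitrogen on an aromatic ring. No measured step makes this particular rearrangement of the fluorines; the steps shown only say that moving a fluorine around the ring can swing this assay in either direction, by a modest to large amount. A modest step toward a higher number is therefore expected, with wide uncertainty. Compound 4 is estimated to give 30 nM, between 6 nM and 200 nM, a step of a 4.0-fold higher number from compound 3 to compound 4 (0.60 log units; beyond the scatter).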

Compound 4, half-maximal inhibitory concentration: 160 nM
For compound 4 the middle estimate is 5.3-fold (0.73 log units) below the measured one; the measured number falls inside the stated range.
By their numbers in this assay, from the lowest: compound 3; then compound 1; then compounds 4 and 2 (each within the scatter of the next).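

The 2,6-difluorophenyl group gives up the gain seen with 2,5-difluorophenyl (a 21-fold higher number from compound 3 to compound 4 (1.33 log units; beyond the scatter)) and also falls short of the single fluorine (an 8.0-fold higher number from compound 1 to compound 4 (0.90 log units; beyond the scatter)), so adding a second fluorine does not in itself help at this position. It cannot be told apart from 2,4-difluorophenyl (a 1.3-fold lower number from compound 2 to compound 4 (0.10 log units; within the scatter)), leaving 2,5-difluorophenyl as the only difluorophenyl shown that improves on 4-fluorophenyl. No evidence given here explains these differences.

Still open, on these data alone, is how a chlorophenyl group, a pyridine ring or a longer chain at this place would compare with compound 3.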